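Cyclopropyl for pyrrolidinyl on the core of compound 1

The source may hold more compounds than are shown below. What is called first, only, known or untested is meant among the compounds shown, and "the series" means these compounds.

Measured compounds:
compound 1, `O=C(Cc1nn(C2CCNC2)c(=O)c2ccccc12)Nc1ccc(OC(F)(F)F)c(Cl)c1`, clearance 16300 mL/min/kg
compound 2, `CCC(C(=O)O)c1nn(Cc2cn3cc(OCC4CC4)c(Cl)cc3n2)c2ccccc2c1=O`, clearance < 56.7 mL/min/kg (a limit)

Among the measured compounds shown here, in an ADME assay on microsomes from liver (Mus musculus) for metabolic stability (on this read-out lower numbers stand for slow clearance and higher numbers for fast clearance), compound 1 gives 16300 mL/min/kg, the only numerical value shown. For compound 2 the assay reports only a limit, < 56.7 mL/min/kg; one of the two results sits at the limit of < 56.7 mL/min/kg in this assay, at which 1 of the 2 values shown sits. For the measured compounds named here, compound 1 therefore stands at the fast end of the two results, while compound 2 gives no number to compare it with, so no step between measured compounds can be drawn.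

Compound 3, `O=C(Cc1nn(C2CC2)c(=O)c2ccccc12)Nc1ccc(OC(F)(F)F)c(Cl)c1`, differs from compound 1 in one place: cyclopropyl in place of pyrrolidin-3-yl on an aromatic nitrogen. Going by the values given here, no measured pair shows what such a change does in this assay, so the expected step from compound 1 to compound 3 rests on the single value of compound 1 alone, which leaves room downward. Compound 3 is expected to clear more slowly, the estimated step being a 3.3-fold lower number from compound 1 to compound 3 (0.51 log units; beyond the scatter), beyond the usual scatter. The clearance of compound 3 in this assay is estimated at 5000 mL/min/kg, within a range of 1000 mL/min/kg to 16000 mL/min/kg.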

Compound 3, clearance: 2300 mL/min/kg
Compound 3: middle estimate off by 2.2-fold (0.34 log units), on the high side, within the range that was stated.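

In this assay, among the compounds shown here, cyclopropyl in place of pyrrolidin-3-yl on the aromatic nitrogen gives a 7.1-fold lower number from compound 1 to compound 3 (0.85 log units; beyond the scatter), the first step that can be read at this position. The group on this nitrogen therefore bears on the read-out, although compound 3 still gives 2300 mL/min/kg, so this one change does not bring the number down to a low value. The change removes a ring nitrogen and shortens the group at the same time, and nothing at hand explains the step.

A cyclopentyl group, which keeps the ring size without the nitrogen, or an azetidin-3-yl group, which keeps the amine in a smaller ring, would be needed to separate those two differences. For the compounds shown here, how much the amide side contributes also stays open, as no pair here changes it.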